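This account rests on a few compounds, and the source may have more. Where it says the series, first, only, none or still open, it means among the compounds named here.

Measured so far in a functional assay on HepG2 cells (Homo sapiens) for antiproliferative activity, read by MTT assay; a lower number here means a stronger inhibitor, a higher number a weaker inhibitor:

- compound 1 `N#Cc1c(F)c(Cl)c(C(C(=O)c2ccc(F)cc2)=C2NCCCN2)c(C#N)c1F`: 45.1 ug/mL
- compound 2 `N#Cc1c(F)c(F)c(C(C(=O)c2ccc(F)cc2)=C2NCCCN2)c(C#N)c1F`: 11 ug/mL
- compound 3 `N#Cc1c(F)c(Cl)c(C(C(=O)c2ccc(F)cc2)=C2NCCCCN2)c(C#N)c1F`: 27.8 ug/mL

Compound 4 `N#Cc1c(F)c(F)c(C(C(=O)c2ccc(F)cc2)=C2NCCCCN2)c(C#N)c1F` has not yet been measured in this assay.

The series carries one structural change twice. From compound 1 to compound 2 the change is fluoro in place of chloro on an aromatic carbon, and in this assay it gave a 4.1-fold lower number from compound 1 to compound 2 (0.61 log units; beyond the scatter). From compound 3 to compound 4 the change is fluoro in place of chloro on an aromatic carbon; the surroundings of the place are described in the same words for both pairs, so this is the same change on a different core. How the core of compound 3 differs from the core of compound 1 is not broken down here. What the values show is that compound 3 and compound 1 lie within the usual scatter of each other in this assay, while compound 2 lies beyond the scatter below compound 3.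

Within the data shown here, for compound 4 the step in this assay is expected to be a 3.5-fold lower number from compound 3 to compound 4 (0.54 log units; beyond the scatter), resting on the single earlier instance of the same change, which in compound 1 to compound 2 gave a 4.1-fold lower number from compound 1 to compound 2 (0.61 log units; beyond the scatter). Because that rests on one pair only, the range is kept wide. Compound 4 is expected to give 8 ug/mL in this assay, with the likely range running from 4 ug/mL to 18 ug/mL.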

Compound 4, half-maximal inhibitory concentration: 24.9 ug/mL
Beside the measured number, compound 4's estimate is 3.1-fold (0.49 log units) below it, and the stated range ends below it.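

In this assay, fluoro in place of chloro on an aromatic carbon gave a 1.1-fold lower number from compound 3 to compound 4 (0.05 log units; within the scatter), so on the core of compound 3 the change does not show the size it showed on the core of compound 1. The two instances of this change differ in size: the same change on two cores in this assay, a 4.1-fold lower number (0.61 log units; beyond the scatter) from compound 1 to compound 2 and a 1.1-fold lower number (0.05 log units; within the scatter) from compound 3 to compound 4, 3.7-fold (0.56 log units) apart, beyond the scatter of two such steps This shows that, in this series, the step seen on one core cannot be carried unchanged to the other; it does not show what produces the gap, and with a single pair on each core it does not show how well either step would repeat or what the same change would do on a third core.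

The compounds shown leave open how bromo, methyl or an amine would behave on the same aromatic carbon, on either core, and thus whether the difference between the two cores is confined to the exchange of chloro for fluoro. They also leave open whether the step would hold if the two cyano groups gave way to a carboxylic acid or an amide, or on any core other than these two.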